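The source may report more compounds than this note shows. Statements on the series, on what has been measured and on what is new or still open speak of the compounds shown alone.

Measured so far:
compound 1, `COc1cc(OC)c(OC)cc1/C=C/C(=O)c1ccc(Cl)cc1`, gives 29500 nM in a functional assay on MCF7 cells (Homo sapiens) for inhibition, read by MTT assay, with a stated time of 72 h; a higher number here means a weaker inhibitor, a lower number a stronger inhibitor.
compound 2, `COc1cc(OC)c(-c2cc(=O)c3cc(Cl)ccc3o2)cc1OC`, gives > 150000 nM in this assay, which is a limit of the assay and not a number.
compound 3, `COc1cc(OC)c(OC)cc1/C=C/C(=O)c1ccc(O)cc1`, gives 182000 nM in this assay.

Compound 1 and compound 3 share one core and differ only by hydroxy in place of chloro on an aromatic carbon. That change gave a 6.2-fold higher number from compound 1 to compound 3 (0.79 log units; beyond the scatter). Compound 4, `COc1cc(OC)c(-c2cc(=O)c3cc(O)ccc3o2)cc1OC`, stands to compound 2 as compound 3 stands to compound 1: it differs by hydroxy in place of chloro on an aromatic carbon. The surroundings are not identical, since here the ring is part of a fused or bridged system of two rings, meta to a fused ring and para to a fused ring, so this is the same kind of change rather than the same change. How the core of compound 1 differs from that of compound 2 is not broken down here. For compound 2 only the limit of > 150000 nM in this assay, at which 1 of the 3 values shown sits, is known.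

The step from compound 2 to compound 4 is expected to be a step that the limit leaves unreadable from compound 2 to compound 4, resting on the step of a 6.2-fold higher number from compound 1 to compound 3 (0.79 log units; beyond the scatter) seen in the other pair. Compound 4 is therefore estimated at 400000 nM, most probably reported again only as a limit.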

Compound 4, half-maximal inhibitory concentration: > 150000 nM
Compound 4: no number, only a limit (the forecaster's own chance of this, stated with the estimate: 85%); the middle value lies beyond the limit too.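

Compound 2 and compound 4 each give only a limit of the assay and not a number, so no step can be read between them: the limit of > 150000 nM in this assay, at which 2 of the 4 values shown sit.

The compounds shown leave open whether hydroxy in place of chloro changes the number on the core of compound 2 as it does on the core of compound 1.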